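Replacing the carbonyl substituent of compound 3

The compounds below may be only part of what the source reports. "The series", "measured", "known", "first", "only" and "open" are said of these compounds alone.

- compound 1 `C[C@H]1CN(c2ccc(Nc3nc4cnc(Nc5cccc(C(F)(F)F)c5)cc4[nH]3)nc2)CCN1`: 71%
- compound 2 `CC(C)CN1CCN(c2ccc(Nc3nc4cnc(NC5CCC(F)(F)CC5)cc4[nH]3)nc2)CC1`: 59%
- compound 3 `O=C(c1ccnc(Nc2nc3cnc(Nc4ccc(F)c(C(F)(F)F)c4)cc3[nH]2)c1)N1CCN(C2CC2)CC1`: 77%

These three compounds were measured in an ADME assay on microsomes from liver (Homo sapiens) for metabolic stability, read by LC-MS, using NADPH, with a stated time of 60 min, tested at 0.1 uM (a lower number here means that less of the compound is left, a higher number that more of the compound is left), and carry different groups on the shared core. Compound 3 gives 77% there. Compound 1 gives 71%, and its gap to compound 3 lies within the usual scatter. Compound 2 gives 59%, and its gap to compound 3 is larger than the usual scatter, with compound 2 on the lower side.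

Compound 4 `C[C@@H]1CN(C(=O)c2ccnc(Nc3nc4cnc(Nc5ccc(F)c(C(F)(F)F)c5)cc4[nH]3)c2)C[C@H](C)O1` remains unmeasured. It has 2,6-dimethylmorpholin-4-yl in place of 4-cyclopropylpiperazin-1-yl on a carbonyl carbon, and the rest of compound 3 stays as it is.

For the measured compounds named here, no two measured compounds differ in one place alone, so the data offer no direct gauge of this swap. The expectation therefore starts from compound 3 at 77% and allows only a modest shift. The expected shift a number 5 percentage points lower from compound 3 to compound 4 (within the scatter) is small and downward and stays within the scatter. The estimated value for compound 4 is 72% with 55% to 86% as its expected bounds.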

Compound 4, percent of the compound remaining: 63%
The estimate for compound 4 lay 9 percentage points above the measured number, and the stated range covers the measured number.
By their numbers in this assay, from the lowest: compounds 2, 4, 1 and 3 (each within the scatter of the next, the first and the last beyond it).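

For the compounds shown here, on a carbonyl carbon whose other neighbour is an aromatic carbon, putting 2,6-dimethylmorpholin-4-yl in place of 4-cyclopropylpiperazin-1-yl gives the first single-place comparison in this assay, and it reads as a number 14 percentage points lower from compound 3 to compound 4 (beyond the scatter) in the percent of compound remaining. The earlier compounds shown here differed in more than one place and could not isolate any group, whereas here the rest of compound 3 stays as it is, so the shift belongs to this one exchange of groups. It also shows that the group on this carbonyl is not neutral for this read-out, although nothing available accounts for the direction or size of the step, and no supporting measurement bears on its cause.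

Which part of the exchange carries the step remains open: the cyclopropyl ring leaves, a ring nitrogen gives way to oxygen, and two methyl groups with defined stereocentres enter, all in a single change. Unsubstituted morpholine, 4-methylpiperazine or dimethylamine on the same carbonyl would help separate these parts, and it is also open whether the step would keep its size with other groups elsewhere on the shared core.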